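A few compounds are considered here, and "the series" means these few. Any claim that something is new, unique, unknown or untested is made for them only; others in the source may bear on it.

Two sulfonamides built on one shared core have been measured. Compound 1 `O=C1CCCCC1S(=O)(=O)Nc1ccccc1Br` carries a bromine on its aromatic ring, while compound 2 `O=C1CCCCC1S(=O)(=O)Nc1ccc(Cl)cc1C(F)(F)F` carries a chloro group together with a trifluoromethyl group. In a functional assay on KB cells (Homo sapiens) for antiproliferative activity, read by sulforhodamine B assay, tested at 100 ug/mL (a lower number here means less inhibition, a higher number more inhibition at the concentration tested (going by the name of the read-out)), compound 1 gives -14.4%, while compound 2 gives 11.2%. Of these two numbers compound 2 stands highest; its nearest neighbour is compound 1, which lies lower by more than the usual scatter of this assay. Both values, however, remain modest at the single concentration tested.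

Compound 3 `O=C1CCCCC1S(=O)(=O)Nc1ccc(Cl)cc1` has not yet been tested. Its difference from compound 2 is hydrogen in place of trifluoromethyl on an aromatic carbon. Among the compounds with values here, no pair of measured compounds shows this kind of change, so nothing measured tells how large its effect should be. Because compound 2 gives only 11.2%, little room remains for a large fall, and the step from compound 2 to compound 3 is expected to be about a number 11.2 percentage points lower from compound 2 to compound 3 (beyond the scatter), within the scatter. For compound 3 in this assay the estimate is 0%, somewhere between -15% and 15%.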

Compound 3, a percentage reported as inhibition, at one concentration (the size of the read-out at that concentration, not a potency): -3.83%
Estimate against measurement, compound 3: 3.8 percentage points above; the range from low to high includes it.
By their numbers in this assay, from the lowest: compound 1; then compound 3; then compound 2.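

In this assay, putting hydrogen in place of trifluoromethyl on this aromatic carbon gives a number 15 percentage points lower from compound 2 to compound 3 (beyond the scatter). Within the data shown here, this is the first measured change at this position, and it shows that the position is not indifferent: with the chloro group kept, compound 2 reads 11.2% and is positive, whereas compound 3 reads -3.83% and is negative. Nothing measured here accounts for the step, so it stands as an observation without an explanation.

A single replacement cannot show whether a methoxy group, a nitrile or an amine on this aromatic carbon would read closer to compound 2 or to compound 3. Also open, from the compounds shown here alone, is whether the same change would give a similar step without the chloro group, or at another test concentration.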